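A few compounds are considered here, and "the series" means these few. Any claim that something is new, unique, unknown or untested is made for them only; others in the source may bear on it.

Measured in a functional assay on HeLa cells (Homo sapiens) for cytotoxicity, read by MTT assay, with a stated time of 2 days, tested at 10 uM; on this read-out lower numbers stand for a stronger effect and higher numbers for a weaker effect at the one concentration tested:

compound 1 `CC(=O)c1cc(-c2ccccc2)cc2cc(-c3ccc(F)cc3)[nH]c12`, 76.9%
compound 2 `CC(=O)c1cc(/C=C/c2ccc(F)cc2)cc2cc(-c3ccccc3)[nH]c12`, 32.8%
compound 3 `CC(=O)c1cc(/C=C/c2ccccc2)cc2cc(-c3ccc(F)cc3)[nH]c12`, 51.9%

Compound 3 stands second highest of the three numbers in this assay: compound 2 lies below it by a gap beyond the scatter, compound 1 above it by a gap beyond the scatter. Within the data shown here, the only single-place step among the measured compounds is a number 25 percentage points lower from compound 1 to compound 3 (beyond the scatter), where a 2-phenylethenyl group replaces phenyl on an aromatic carbon and the number drops modestly.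

Compound 4 `CC(=O)c1cc(/C=C/c2ccc(F)cc2)cc2cc(-c3ccc(F)cc3)[nH]c12` is not yet measured. It differs from compound 3 by fluoro in place of hydrogen on an aromatic carbon. Among the measured compounds shown here, no measured step addresses this change in isolation. Compound 2 and compound 3 differ in two places at once, so their values only show that a fluorine on the ethenyl-bearing aryl ring, with none on the other aryl, goes together with a lower number than the reverse arrangement. The share of each fluorine in that gap cannot be separated from these two values.

For the measured compounds named here, with no direct precedent, the expectation for compound 4 in this assay is a small change, leaning lower, within or just beyond the scatter: a number 9.9 percentage points lower from compound 3 to compound 4 (within the scatter). The estimate for compound 4 is 42%, with a range from 25% to 60%.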

Compound 4, a percentage reported as activity, at one concentration (the size of the read-out at that concentration, not a potency): 41.9%
For compound 4 the middle estimate is 0.1 percentage points above the measured one; low and high end bracket the measured number.
By their numbers in this assay, from the lowest: compounds 2, 4 and 3 (each within the scatter of the next, the first and the last beyond it); then compound 1.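

In this assay fluoro in place of hydrogen now has a single-place reading on each aryl group: on the 2-phenylethenyl group it gives a number 10 percentage points lower from compound 3 to compound 4 (within the scatter) and on the phenyl group it gives a number 9.1 percentage points higher from compound 2 to compound 4 (within the scatter) as its counterpart. Each fluorine taken alone therefore stays within the scatter, so neither exchange can be told apart from repeat measurement in this series. The change that clears the scatter is the replacement of phenyl by the ethenyl-linked aryl group: 2-(4-fluorophenyl)ethenyl gives a number 35 percentage points lower from compound 1 to compound 4 (beyond the scatter) and this goes the same way as the step with the plain 2-phenylethenyl group, a number 25 percentage points lower from compound 1 to compound 3 (beyond the scatter) so the direction holds with the fluoro present.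

The compounds shown leave open whether a chloro, a methoxy or an amine at the fluoro's place would give a step beyond the scatter, and whether a saturated chain in place of the ethenyl link would keep the step from phenyl. No evidence on the reason for any of these steps is at hand.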